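The source may hold more compounds than are shown below. What is called first, only, known or untested is meant among the compounds shown, and "the series" means these compounds.

Measured so far:
compound 1 `O=C1O[C@H]([C@@H](O)Cn2cc(-c3cc(C(F)(F)F)cc(C(F)(F)F)c3)nn2)C(OCc2ccccc2)=C1OCc1ccccc1` — 49200 nM
compound 2 `Cc1ccc(-c2cn(C/C=C3\OC(=O)C(OCc4ccccc4)=C3OCc3ccccc3)nn2)cc1` — > 100000 nM
compound 3 `O=C1O[C@H]([C@@H](O)Cn2cc(-c3cccc(O)c3)nn2)C(OCc2ccccc2)=C1OCc1ccccc1` — > 100000 nM

Among the compounds with values here, in a functional assay on SW-620 cells (Homo sapiens) for antiproliferative activity, read by MTT assay, with a stated time of 72 h (a lower number here means a stronger inhibitor, a higher number a weaker inhibitor), compound 1 gives 49200 nM, the only numerical reading of the three. For compound 2 the value > 100000 nM is a limit of the assay, not a number. For compound 3 the value > 100000 nM is likewise a limit, so that compound 3 stands at the limit of > 100000 nM in this assay, at which 2 of the 3 values shown sit, together with compound 2, and its distance to compound 1 cannot be stated beyond that compound 1 returned a number where compound 3 did not.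

Compound 4 `C[Si](C)(C)c1cn(C[C@H](O)[C@H]2OC(=O)C(OCc3ccccc3)=C2OCc2ccccc2)nn1` is not yet measured in this assay. It differs from compound 3 in one place: a group of 4 heavy atoms (3 carbon, 1 silicon; no ring) in place of a group of 7 heavy atoms (6 carbon, 1 oxygen; one six-membered aromatic ring of carbon only), on an aromatic carbon. Between compound 3 and compound 4 no measured step is available, and no pair of measured compounds separated by a single change exists in this set.

Given that two of the three readings sit at the limit, compound 4 is expected to remain weak; the step of an at least 1.1-fold lower number from compound 3 to compound 4 (0.04 log units; that floor lies within the scatter) is expected to be small, without a clear direction beyond the scatter. Compound 4 is estimated at 90000 nM, within 35000 nM to 250000 nM, with a fair chance that only a limit is returned.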

Compound 4, half-maximal inhibitory concentration: 56000 nM
For compound 4 the middle estimate is 1.6-fold (0.21 log units) above the measured one; the range from low to high includes it.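

In this assay the series gains its first single-change pair, with the 3-hydroxyphenyl group giving way to a group of 4 heavy atoms (3 carbon, 1 silicon; no ring) on the aromatic carbon of the five-membered ring, and the step is an at least 1.7-fold lower number from compound 3 to compound 4 (0.25 log units; that floor lies within the scatter) as a floor only. A ring in this group is not needed for a numerical reading, since compound 4 gives 56000 nM without one. Compound 3 gives > 100000 nM as a limit and not a number, so the true step may be larger, and this limit recurs in the set: the limit of > 100000 nM in this assay, at which 2 of the 4 values shown sit.

The compounds shown do not separate the loss of the hydroxyl from the loss of the ring. On these data alone, how a tert-butyl group, an unsubstituted phenyl or an amine on this carbon would read also stays open.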